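A few compounds are considered here, and "the series" means these few. Any claim that something is new, unique, unknown or untested is made for them only; others in the source may bear on it.

Working notes on the series. The core shared by all members is shown in compound 2 `COc1ccccc1-c1cc(C2CCNC2)ccc1Cl`, which in an assay on isolated protein for binding affinity to 5-hydroxytryptamine receptor 1B (Homo sapiens) (on this read-out lower numbers stand for stronger inhibition and higher numbers for weaker inhibition), gives 410 nM. For the measured compounds named here, this is the only number among the three values shown; the other two are limits of the assay. Compound 1 `CCCN(CCC)Cc1ccc(Cl)c(-c2ccccc2OC)c1` in this assay sits at the limit > 10000 nM. Compound 3 `CCCCNCc1ccc(Cl)c(-c2ccccc2OC)c1` in this assay sits at the limit > 10000 nM. Going by the values given here, the one readable step is an at least 24-fold higher number from compound 2 to compound 3 (1.38 log units; beyond the scatter), a large loss when the ring-bound amine is opened into an aminomethyl chain. The step that the two limits leave unreadable from compound 1 to compound 3 cannot be sized, since both ends are limits.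

Compound 4 `CCN(CC)Cc1ccc(Cl)c(-c2ccccc2OC)c1` is not yet measured. It differs from compound 2 by (diethylamino)methyl in place of pyrrolidin-3-yl on an aromatic carbon. Among the compounds with values here, the change runs in the same direction as the one from compound 2 to compound 3, and compound 4 resembles compound 1 in carrying two alkyl branches on the aminomethyl nitrogen. The step of an at least 24-fold higher number from compound 2 to compound 3 (1.38 log units; beyond the scatter) points the same way. Compound 1 sits at the limit > 10000 nM. Taken together, a large rise in this assay is expected for compound 4, in the range of a 24-fold higher number from compound 2 to compound 4 (1.39 log units; beyond the scatter). The estimate for compound 4 in this assay is 10000 nM, between 3000 nM and 40000 nM, with a fair chance that the assay again reports only (the limit of > 10000 nM in this assay, at which 2 of the 3 values shown sit).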

Compound 4, inhibition constant: > 10000 nM
Compound 4 gave a limit, no number; the forecaster's own chance of this, stated with the estimate: 60%; the middle value lies on the limit itself.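

In this assay, putting (diethylamino)methyl in place of pyrrolidin-3-yl on the aromatic carbon para to the chloro group gives an at least 24-fold higher number from compound 2 to compound 4 (1.38 log units; beyond the scatter), a large step beyond the scatter. The earlier readable step came from a butylamino chain with a hydrogen still on its nitrogen, so this result shows that the loss also appears with two ethyl branches on the nitrogen and with a smaller open-chain group than the dipropylamino one in compound 1. The steps among compound 1, compound 3 and compound 4 cannot be read, as each joins two limits, and all the open-chain amines shown, with no compound going against this, end at the same assay limit: the limit of > 10000 nM in this assay, at which 3 of the 4 values shown sit.

As far as these compounds go, how far these three compounds actually lie from compound 2 stays unknown, and so does any order among them. The compounds shown also leave open whether a ring amine other than pyrrolidin-3-yl, such as a piperidine or an azetidine, keeps a readable number at this place, and whether a primary aminomethyl group does the same.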